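A few compounds are considered here, and "the series" means these few. Any claim that something is new, unique, unknown or untested is made for them only; others in the source may bear on it.

Measured so far:
compound 1 `COc1ccc(-c2nsc3c2NC(=O)CC3c2cccc(Cl)c2)cc1` – > 2000 nM
compound 2 `COc1ccc(-c2nsc3c2NC(=O)CC3c2cccc(F)c2)cc1` – > 2000 nM

In a functional assay on NCI-H1975 cells (Homo sapiens) for antiproliferative activity, read by CellTiter-Glo, with a stated time of 96 h (a higher number here means a weaker inhibitor, a lower number a stronger inhibitor), compound 1 gives > 2000 nM, which is a limit of the assay rather than a number. Compound 2 gives > 2000 nM, likewise a limit. Both sit at the limit of > 2000 nM in this assay, at which 2 of the 2 values shown sit, leaving a step that the two limits leave unreadable from compound 1 to compound 2. Compound 3 `COc1ccc(-c2nsc3c2NC(=O)CC3c2ccsc2)cc1` differs from compound 2 by thiophen-3-yl in place of 3-fluorophenyl on a saturated ring carbon. Among the compounds with values here, no measured step bears on this change, and compound 2 itself offers only a limit, so no step beyond the scatter can be expected in either direction. Compound 3 is therefore estimated at 3000 nM, with a range from 1000 nM to 10000 nM, an expected step that the limit leaves unreadable from compound 2 to compound 3.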

Compound 3, half-maximal inhibitory concentration: 254 nM
For compound 3 the middle estimate is 12-fold (1.07 log units) above the measured one, and the stated range ends above it.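

At this saturated ring carbon, the ring carried does matter in this assay: the earlier pair allowed no reading, whereas thiophen-3-yl gives an at least 7.8-fold lower number from compound 2 to compound 3 (0.89 log units; beyond the scatter) and an at least 7.8-fold lower number from compound 1 to compound 3 (0.89 log units; beyond the scatter). Within the data shown here, compound 3 is the first compound here with a true number rather than a limit. Both steps are only minimum sizes, because compound 1 and compound 2 rest on a limit: the limit of > 2000 nM in this assay, at which 2 of the 3 values shown sit.

From the compounds shown here alone, it remains open whether the gain belongs to the sulfur or to the five-membered aromatic ring, a question furan-3-yl could address. Also open, going by these compounds, is how an amine or a carboxylic acid on that ring would fare.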